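Anilide series: pyridin-3-yl for phenyl, expectation for compound 4

The compounds below may be only part of what the source reports. "The series", "measured", "known", "first", "only" and "open" are said of these compounds alone.

compound 1 `COc1cc2c(cc1OC)C(CC(=O)Nc1ccccc1)CC2`: 37.5%
compound 2 `COc1cc2c(cc1OC)C(CC(=O)Nc1ccc(Cl)cc1)CC2`: 60.9%
compound 3 `COc1cc2c(cc1OC)C(CC(=O)Nc1ccc(Br)cc1)CC2`: 40.6%

In a functional assay on the whole organism (strain Wistar) for inhibition, with Rattus norvegicus as the target, read by paw edema, with a stated time of 4 h, at a dose of 100 mg/kg (on this read-out lower numbers stand for less inhibition and higher numbers for more inhibition at the one dose given (going by the name of the read-out)), compound 1 gives 37.5% and stands at the low end of the three numbers. Compound 3 sits within the scatter of it, the step being a number 3.1 percentage points higher from compound 1 to compound 3 (within the scatter). Compound 2 stands apart: a number 23.4 percentage points higher from compound 1 to compound 2 (beyond the scatter), and against compound 3 the step is a number 20.3 percentage points lower from compound 2 to compound 3 (beyond the scatter). All three measured steps concern a halogen on an aromatic carbon of the anilide ring, with the ring itself unchanged.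

Compound 4 `COc1cc2c(cc1OC)C(CC(=O)Nc1cccnc1)CC2` is not yet measured. From compound 1 it differs by pyridin-3-yl in place of phenyl on an amide-type nitrogen. For the measured compounds named here, no measured step exchanges the ring for a heteroaryl ring, so the halogen steps do not bear on it directly; they show only that single changes on this ring move the read-out by modest amounts or not at all. With nothing pointing in either direction, the expectation is a step of no clear size beyond the scatter, a number 0.5 percentage points higher from compound 1 to compound 4 (within the scatter), and a wide range around it. Compound 4 is therefore estimated at 38%, with a range from 18% to 60%.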

Compound 4, a percentage reported as inhibition, in the whole organism at one dose (the size of the read-out at that dose, not a potency): 34.4%
Estimate against measurement, compound 4: 3.6 percentage points above; low and high end bracket the measured number.
By their numbers in this assay, from the lowest: compounds 4, 1 and 3 (each within the scatter of the next); then compound 2.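

In this assay, for the compounds shown here, the first change to the ring itself on the amide-type nitrogen gives a number 3.1 percentage points lower from compound 1 to compound 4 (within the scatter), so pyridin-3-yl in place of phenyl, which brings one ring nitrogen and one hydrogen-bond acceptor by the count, does not separate from the parent anilide. Against the bromo anilide the picture is the same, with a number 6.2 percentage points lower from compound 3 to compound 4 (within the scatter), while the chloro anilide remains the one member set apart from the rest, with a number 26.5 percentage points lower from compound 2 to compound 4 (beyond the scatter). Nothing measured on these compounds gives a reason for any of these steps.

Still open, on these data alone, is whether chloro on the pyridin-3-yl ring would give the same step as chloro on the phenyl ring, and whether pyridin-2-yl or pyridin-4-yl would read like pyridin-3-yl. Also open, as far as these compounds go, is whether a methoxy group or a carboxylic acid on the anilide ring, or a longer chain carrying the amide on the shared core, would move the read-out beyond the scatter.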